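Swapping Chlorine for Fluorine on a Benzimidazole Antagonist

The source may hold more compounds than are shown below. What is called first, only, known or untested is meant among the compounds shown, and "the series" means these compounds.

Measured compounds:
Compound 1, `CN1CCN(CCCN(c2nc3cc(F)c(F)cc3[nH]2)[C@@H]2CC[C@]3(c4cccc(CN5CCCCC5)c4)C[C@@H]3C2)CC1`, 405 nM
Compound 2, `CN1CCN(CCCN(c2nc3cc(Cl)c(Cl)cc3[nH]2)[C@@H]2CC[C@]3(c4cccc(C#N)c4)C[C@@H]3C2)CC1`, 2.2 nM

Of the compounds shown here, two have been tested in an assay on CHO cells for antagonist activity at melanin-concentrating hormone receptor 1 (Homo sapiens), read by luminescence and calcium flux, with a stated time of 10 min; on this read-out lower numbers stand for stronger inhibition and higher numbers for weaker inhibition. Compound 2 shows the lowest number of the pair, and its nearest neighbour, compound 1, sits far higher, a gap well beyond the usual scatter. Compound 1 and compound 2 differ in two places at once, so no single change can be read from that gap. The next compound, compound 3, `CN1CCN(CCCN(c2nc3cc(F)c(F)cc3[nH]2)[C@@H]2CC[C@]3(c4cccc(C#N)c4)C[C@@H]3C2)CC1`, differs from compound 2 in one place: 5,6-difluoro-1H-benzimidazol-2-yl in place of 5,6-dichloro-1H-benzimidazol-2-yl on an amine nitrogen. Compound 1 carries the same difluoro group, but its other difference from compound 2 keeps it from serving as a direct comparison. Halogen swaps of this kind usually shift this assay only modestly, so for compound 3 a small loss, not far beyond the scatter, is expected, a 3.2-fold higher number from compound 2 to compound 3 (0.50 log units; beyond the scatter). For compound 3 the estimated value is 7 nM, within a range from 2 nM to 30 nM.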

Compound 3, half-maximal inhibitory concentration: 21 nM
Compound 3: the middle estimate sits 3.0-fold (0.48 log units) below what was measured, within the range that was stated.
By their numbers in this assay, from the lowest: compound 2; then compound 3; then compound 1.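

Compound 3 isolates the halogen change, which compound 1 could not do: in this assay, 5,6-difluoro-1H-benzimidazol-2-yl in place of 5,6-dichloro-1H-benzimidazol-2-yl on the amine nitrogen gives a 9.5-fold higher number from compound 2 to compound 3 (0.98 log units; beyond the scatter) with the rest of the molecule unchanged. This position therefore responds to the identity of the two halogens, and chlorine gives the lower number in this pair. Compound 3 also isolates the other change, since cyano in place of (piperidin-1-yl)methyl on an aromatic carbon gives a 19-fold lower number from compound 1 to compound 3 (1.29 log units; beyond the scatter) with the difluoro group held fixed, though nothing here explains either step.

From the compounds shown here alone, whether bromine atoms or methyl groups at the same places would match the chlorine atoms remains open. So does how an amide or a carboxylic acid would compare with cyano on that aromatic carbon.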